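Methoxy in Place of Fluoro on the Benzyl Ring

The source may hold more compounds than are shown below. What is called first, only, known or untested is meant among the compounds shown, and "the series" means these compounds.

Among the measured compounds shown here, compound 1 `O=C(O)c1ccccc1-c1ccc(CCc2ncc(Cc3ccccc3F)[nH]2)cc1` is one of two compounds measured in an in vitro functional assay on cells for agonist activity at Bombesin receptor subtype-3 (Homo sapiens), read by luminescence and calcium flux; on this read-out lower numbers stand for an effect already at smaller amounts and higher numbers for an effect only at larger amounts of compound; in this assay compound 1 gives 177 nM, the lowest of the two numbers. Compound 2 `CCCCc1cnc(C(CC)Cc2ccc(-c3ccccc3C(=O)O)cc2)[nH]1` gives 2720 nM in this assay, a number that lies well beyond the scatter from that of compound 1. For the measured compounds named here, no single-point step is recorded between these two, which differ in several places at once.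

Compound 3 `COc1ccccc1Cc1cnc(CCc2ccc(-c3ccccc3C(=O)O)cc2)[nH]1` has not yet been measured. It differs from compound 1 in one place: methoxy in place of fluoro on an aromatic carbon. The change sits on an aromatic carbon of a six-membered aromatic ring of carbon only, ortho to a large group.

With only compound 1 as an anchor, the step is expected to be small: a 1.7-fold higher number from compound 1 to compound 3 (0.23 log units; within the scatter) is estimated to stay within or just beyond the scatter, toward a somewhat higher number. Compound 3 is therefore expected to give 300 nM in this assay, with a range from 100 nM to 900 nM.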

Compound 3, half-maximal effective concentration: 1720 nM
Beside the measured number, compound 3's estimate is 5.7-fold (0.76 log units) below it; measured number above the stated range.
By their numbers in this assay, from the lowest: compound 1; then compounds 3 and 2 (each within the scatter of the next).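

In this assay, the change from 2-fluorobenzyl to 2-methoxybenzyl gives a 9.7-fold higher number from compound 1 to compound 3 (0.99 log units; beyond the scatter). Among the compounds shown here, this is the first single-point step in the set, and it shows that this place on the six-membered aromatic ring, ortho to a large group, responds to the change, with the rest of the structure held the same. The earlier pair differed in several places at once and could not show this for any one place. No measurement at hand bears on the cause of this step.

The compounds shown leave open how a hydroxy, a methyl or a chloro group would read at this place, which would help separate the part played by the oxygen from that of the added carbon. They also leave open whether a longer ether such as ethoxy would follow methoxy.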